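Chloro to bromo at the edge of an assay limit

The source may report more compounds than this note shows. Statements on the series, on what has been measured and on what is new or still open speak of the compounds shown alone.

In an ADME assay on L02 cells (Homo sapiens) for cytotoxicity, read by MTT assay, with a stated time of 24 h (on this read-out higher numbers stand for weaker inhibition and lower numbers for stronger inhibition), compound 1 `O=C1/C(=C/c2cccnc2)CN(S(=O)(=O)c2ccccc2)C/C1=C\c1ccccc1F` gives 15300 nM and compound 2 `Cc1ccc(S(=O)(=O)N2C/C(=C\c3cccnc3)C(=O)/C(=C/c3ccccc3F)C2)cc1` gives 14900 nM with the two lying within the scatter of each other. Compound 3 `O=C1/C(=C/c2cccnc2)CN(S(=O)(=O)c2ccc(Cl)cc2)C/C1=C\c1ccccc1F` yields no number, only the limit > 20000 nM of the measurement.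

Compound 4 `O=C1/C(=C/c2cccnc2)CN(S(=O)(=O)c2ccc(Br)cc2)C/C1=C\c1ccccc1F` replaces the chloro of compound 3 with bromo, on an aromatic carbon para to a large group (bromo in place of chloro on an aromatic carbon). Three measured steps at this same place bear on the change. Methyl in place of hydrogen gave a 1.0-fold lower number from compound 1 to compound 2 (0.01 log units; within the scatter) and chloro in place of hydrogen gave an at least 1.3-fold higher number from compound 1 to compound 3 (0.11 log units; that floor lies within the scatter) while chloro in place of methyl gave an at least 1.3-fold higher number from compound 2 to compound 3 (0.12 log units; that floor lies within the scatter) so none of them is shown to go beyond the scatter.

On these steps, no change beyond the scatter is expected in this assay and the estimated step is a number no higher from compound 3 to compound 4 (the limit leaves the size open) in either direction. Compound 4 is estimated at 20000 nM within an expected range of 12000 nM to 35000 nM. It is expected that this compound may again give only a limit.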

Compound 4, half-maximal inhibitory concentration: 14600 nM
Estimate against measurement, compound 4: 1.4-fold (0.14 log units) above, within the range that was stated.
By their numbers in this assay, from the lowest: compounds 4, 2 and 1 (each within the scatter of the next). At a limit, above all of these: compound 3.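

In this assay, a bromo group on this aromatic carbon gives a readable number, and it can be set against the groups already measured there: bromo in place of hydrogen gives a 1.0-fold lower number from compound 1 to compound 4 (0.02 log units; within the scatter), and bromo in place of methyl gives a 1.0-fold lower number from compound 2 to compound 4 (0.01 log units; within the scatter). Hydrogen, methyl and bromo therefore cannot be told apart on this read-out, whereas the earlier compounds could show this only for hydrogen and methyl. Bromo in place of chloro gives an at least 1.3-fold lower number from compound 3 to compound 4 (0.13 log units; that floor lies within the scatter), which is a floor only, because the chloro value is a limit and not a number: the limit of > 20000 nM in this assay, at which 1 of the 4 values shown sits.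

Going by these compounds, whether chloro truly differs from the other three groups remains open. Also open, on these data alone, is whether an amine, a carboxylic acid or a methoxy group on this aromatic carbon would move the number beyond the scatter.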